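Piperazine Substituent Change in a Dithiocarbamate Series

This account rests on a few compounds, and the source may have more. Where it says the series, first, only, none or still open, it means among the compounds named here.

Measured compounds:
compound 1, `Nc1ccccc1NC(=O)c1ccc(CSC(=S)N2CCN(Cc3ccccn3)CC2)cc1`, 65.2%
compound 2, `Nc1ccccc1NC(=O)c1ccc(CSC(=S)N2CCc3cc([N+](=O)[O-])ccc32)cc1`, 33.2%
compound 3, `Nc1ccccc1NC(=O)c1ccc(CSC(=S)N2CCc3cc(Cl)ccc32)cc1`, 82.2%

In a functional assay on MGC-803 cells (Homo sapiens) for antiproliferative activity, read by CCK-8 assay, with a stated time of 72 h, tested at 8 uM (a lower number here means a weaker effect, a higher number a stronger effect of the compound at the concentration tested), compound 1 gives 65.2%, the second highest of the three numbers. Its nearest neighbour is compound 3, which gives 82.2%, and the furthest is compound 2 with 33.2%; both gaps to compound 1 lie beyond the scatter.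

Compound 4, `Cc1ccc(N2CCN(C(=S)SCc3ccc(C(=O)Nc4ccccc4N)cc3)CC2)cc1`, has not yet been measured. It differs from compound 1 in one place: 4-methylphenyl in place of (pyridin-2-yl)methyl on an amine nitrogen in a ring.

Among the compounds with values here, the only measured step between neighbours, a number 49 percentage points higher from compound 2 to compound 3 (beyond the scatter), concerns a substituent on a different ring of the shared core and does not touch the position changed here. Within the data shown here, no measured pair bears directly on the change from compound 1 to compound 4, so there is no firm basis to expect a step in either direction beyond the scatter, though the single known step shows that this series can move widely with a small change. The number for compound 4 is therefore expected to sit near that of compound 1, with a wide range: 62%, between 40% and 82%, which would mean an estimated step of a number 3.2 percentage points lower from compound 1 to compound 4 (within the scatter).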

Compound 4, a percentage reported as inhibition, at one concentration (the size of the read-out at that concentration, not a potency): 19.8%
Estimate against measurement, compound 4: 42.2 percentage points above; measured number outside the range, below it.
By their numbers in this assay, from the lowest: compound 4; then compound 2; then compound 1; then compound 3.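

In this assay the group on the amine nitrogen in the six-membered non-aromatic ring proves decisive for the read-out, with a number 45.4 percentage points lower from compound 1 to compound 4 (beyond the scatter) when 4-methylphenyl takes the place of (pyridin-2-yl)methyl. Within the data shown here, the earlier step lay on a different ring of the shared core, so this is the first reading at this position, and it shows that an exchange leaving the count of 7 heavy atoms and the single six-membered aromatic ring unchanged can still cost a large part of the effect. What the exchange does alter is the ring content, from a ring with 1 hetero atom and 1 hydrogen-bond acceptor to a ring of carbon only with no acceptor, and the attachment of that ring to the nitrogen, but no measurement given here explains the loss.

Among these compounds, the single step changes these features together, so the contribution of each remains open. A benzyl group or a directly attached pyridin-2-yl group on the same nitrogen would separate the ring content from the carbon link, and a plain phenyl group would isolate the role of the methyl substituent.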